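This account rests on a few compounds, and the source may have more. Where it says the series, first, only, none or still open, it means among the compounds named here.

Measured in a functional assay on MCF7 cells (Homo sapiens) for antiproliferative activity, read by MTT assay, with a stated time of 72 h; on this read-out lower numbers stand for stronger inhibition and higher numbers for weaker inhibition:
- Compound 1 `CC1=CC[C@H]2[C@@H]1CC=C(C)[C@@H](CCC1=C(C)CC[C@@H]3OC(C)(C)[C@@H](O)CC[C@@]13C)C2(C)C`: > 50000 nM
- Compound 2 `CC1=CC[C@H]2[C@H](CC[C@]2(C)O)C(C)(C)[C@@H]1CC[C@H]1[C@]2(C)CC[C@H](OC(=O)CCC(=O)O)C(C)(C)O[C@H]2CC[C@@]1(C)O`: > 50000 nM
- Compound 3 `CC1=CC[C@H]2[C@@H]1CC=C(C)[C@@H](CC[C@H]1[C@]3(C)CC[C@H](OC(=O)CCC(=O)O)C(C)(C)O[C@H]3CC[C@@]1(C)O)C2(C)C`: > 50000 nM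

The picture so far is flat, with the limit of > 50000 nM in this assay, at which 3 of the 3 values shown sit. None of these compounds has yet given a true number, and so their order cannot be told. Compound 3 stands at > 50000 nM, which is a limit and not a number.

Compound 4 `CC1=CC[C@H]2[C@@H]1CC=C(C)[C@@H](CC[C@H]1[C@]3(C)CC[C@H](OC(=O)c4ccncc4)C(C)(C)O[C@H]3CC[C@@]1(C)O)C2(C)C` keeps the core of compound 3 and carries pyridin-4-yl in place of 2-carboxyethyl on a carbonyl carbon. Among the measured compounds shown here, no measured pair shows what a change of this kind does in this assay, so any expectation is a cautious one. A modest gain in inhibition is expected, toward lower numbers, bringing the value just inside the measurable range, though another limit would be no surprise. The expected step of an at least 1.6-fold lower number from compound 3 to compound 4 (0.22 log units; that floor lies within the scatter) is therefore small. For compound 4 the estimated value is 30000 nM, with an expected range of 10000 nM to 50000 nM.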

Compound 4, half-maximal inhibitory concentration: > 50000 nM
Compound 4 was reported as a limit; the forecaster's own chance of this, stated with the estimate: 45%; at least 1.6-fold (0.22 log units) between middle value and limit.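

In this assay compound 4 gives > 50000 nM, which is a limit and not a number; compound 3 is also reported as a limit, so no step can be read between them. The compounds shown leave open which change, if any, would give a true number, since all remain at the limit: the limit of > 50000 nM in this assay, at which 4 of the 4 values shown sit.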